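Replacing an ethynylphenyl arm on the shared amide-type ring nitrogen

The source may hold more compounds than are shown below. What is called first, only, known or untested is meant among the compounds shown, and "the series" means these compounds.

The series rests on a common core carrying a five-membered non-aromatic ring with one nitrogen and one sulfur, and the compounds differ in the group on the amide-type nitrogen in that ring and in the amide side chain. Compound 1 `COc1ccccc1N1C(=O)C(C)SC1c1cccc(C(=O)NCCCCc2ccccc2)c1` is the fastest-cleared member in an ADME assay on microsomes from liver (Rattus norvegicus) for metabolic stability, read by LC-MS, using NADPH, with a stated time of 10 min, tested at 0.1 uM; on this read-out higher numbers stand for fast clearance and lower numbers for slow clearance; compound 1 gives 2910 mL.min-1.g-1. Compound 2 `O=C(NCCCCn1cccn1)c1cccc(C2SCC(=O)N2c2ccccn2)c1` sits lowest, and in this assay compound 2 gives 506 mL.min-1.g-1. Compound 3 `C#Cc1cccc(N2C(=O)CSC2c2cccc(C(=O)NCCCCc3ccccc3)c2)c1` stands second highest of the three: in this assay compound 3 gives 1820 mL.min-1.g-1, a number within the scatter of compound 1 but beyond the scatter of compound 2, which is lower.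

Compound 4 `O=C(NCCCCc1ccccc1)c1cccc(C2SCC(=O)N2c2ccccc2F)c1` has not yet been measured. It differs from compound 3 in one place: 2-fluorophenyl in place of 3-ethynylphenyl on an amide-type nitrogen in a ring. Among the compounds with values here, no step between two measured compounds matches this change, so the expectation rests on compound 3 alone. The step of a 1.5-fold lower number from compound 3 to compound 4 (0.18 log units; within the scatter) is expected to be small and downward, possibly not beyond the scatter. Compound 4 is therefore estimated to give 1200 mL.min-1.g-1 in this assay, with a likely range from 500 mL.min-1.g-1 to 2800 mL.min-1.g-1.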

Compound 4, intrinsic clearance in microsomes: 2950 mL.min-1.g-1
Estimate against measurement, compound 4: 2.5-fold (0.39 log units) below; measured number outside the range, above it.
By their numbers in this assay, from the lowest: compound 2; then compounds 3, 1 and 4 (each within the scatter of the next).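

In this assay, within the data shown here, putting 2-fluorophenyl in place of 3-ethynylphenyl on an amide-type nitrogen in a ring gives a 1.6-fold higher number from compound 3 to compound 4 (0.21 log units; within the scatter), the first comparison in this set in which only one place differs. With the amide side chain and the rest of the shared core held the same, this exchange, which removes the triple bond outside aromatic rings and brings in a fluorine, leaves the read-out within the scatter, so the two groups cannot be told apart here. No measurement shown here bears on why compound 3 and compound 4 cannot be separated.

Compound 2 differs from compound 3 and compound 4 both at this nitrogen and in the amide side chain, so its place in the series cannot be assigned to either change alone. Still open, going by these compounds, is whether any group at this nitrogen moves the number beyond the scatter when the side chain stays fixed, for instance a phenyl ring carrying an amine or a carboxylic acid.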